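This account rests on a few compounds, and the source may have more. Where it says the series, first, only, none or still open, it means among the compounds named here.

Compounds measured so far:
compound 1 `COC(=O)C1=C(C)NC(=O)NC1c1cccs1`: 3%
compound 2 `CCCOC(=O)C1=C(C)NC(=O)NC1c1cccs1`: 32%
compound 3 `CC1=C(C(=O)OC(C)(C)C)C(c2cccs2)NC(=O)N1`: 7%

Three esters sharing one core have been tested in an assay on membranes from HeLa cells for displacement of a labelled ligand from adenosine receptor A3 (Homo sapiens), read by scintillation counting, with a stated time of 180 min, tested at 1 uM; a higher number here means more inhibition at the concentration tested (going by the name of the read-out), a lower number less inhibition. Compound 3 stands second highest of the three numbers: its nearest neighbour is compound 1, with a step of a number 4 percentage points higher from compound 1 to compound 3 (within the scatter), and its furthest is compound 2, with a step of a number 25 percentage points lower from compound 2 to compound 3 (beyond the scatter). Among the measured compounds shown here, the one change that clearly moved the read-out so far is a number 29 percentage points higher from compound 1 to compound 2 (beyond the scatter).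

The next compound, compound 4 `CC1=C(C(=O)OCc2ccccc2)C(c2cccs2)NC(=O)N1`, is not yet measured. It differs from compound 3 in one place: benzyl in place of tert-butyl on an oxygen next to a carbonyl group.

Two earlier steps bear on this change, both altering the same ester group: a number 29 percentage points higher from compound 1 to compound 2 (beyond the scatter) and a number 25 percentage points lower from compound 2 to compound 3 (beyond the scatter). Both were modest in size and beyond the scatter, with a longer chain raising the number and a branched group lowering it again. Benzyl is the largest group tried here, so a modest rise is expected for compound 4, an expected step of a number 13 percentage points higher from compound 3 to compound 4 (beyond the scatter) in this assay. Compound 4 is therefore estimated at 20%, expected to lie between 3% and 45%.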

Compound 4, a percentage reported as inhibition, at one concentration (the size of the read-out at that concentration, not a potency): 8%
The estimate for compound 4 lay 12 percentage points above the measured number; low and high end bracket the measured number.
By their numbers in this assay, from the lowest: compounds 1, 3 and 4 (each within the scatter of the next); then compound 2.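

On the oxygen next to a carbonyl group, benzyl in place of tert-butyl leaves the read-out in this assay level (a number 1 percentage points higher from compound 3 to compound 4 (within the scatter)), even though benzyl brings more heavy atoms and a six-membered aromatic ring. Phenyl on the saturated chain carbon likewise shows no clear difference when it replaces hydrogen (a number 5 percentage points higher from compound 1 to compound 4 (within the scatter)), but it gives a clear drop when it replaces ethyl (a number 24 percentage points lower from compound 2 to compound 4 (beyond the scatter)), so among these four esters only the propyl ester, compound 2, stands apart, and adding heavy atoms alone does not raise the number, as compound 3 and compound 4 show. Nothing measured here offers a reason for this.

Going by these compounds, what a shorter straight chain such as ethyl, or a longer one such as butyl, would give on this oxygen remains open. So does the effect of an amine on the propyl chain.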